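The source may hold more compounds than are shown below. What is called first, only, known or untested is meant among the compounds shown, and "the series" means these compounds.

Compound 1 `CC(c1ccc(-c2ccccc2)c(F)c1)c1nnc2n1N=C(c1ccc(Cl)cc1Cl)CS2` gives 4200 nM in a functional assay on Hep 3B2 cells (Homo sapiens) for inhibition, read by sulforhodamine B assay, with a stated time of 72 h; a higher number here means a weaker inhibitor, a lower number a stronger inhibitor.
Compound 2 `COc1ccc(C2=Nn3c(nnc3C(C)c3ccc(-c4ccccc4)c(F)c3)SC2)cc1` gives 3500 nM in this assay.

Compound 2 and compound 1 sit within the scatter of each other; of the two numbers, compound 2 has the lower one, but the step of a 1.2-fold lower number from compound 1 to compound 2 (0.08 log units; within the scatter) is too small to count as a real change. Compound 3 `CC(c1ccc(-c2ccccc2)c(F)c1)c1nnc2n1N=C(c1ccc(Cl)cc1)CS2` differs from compound 2 by chloro in place of methoxy on an aromatic carbon, on the phenyl ring that hangs from the carbon with a double bond to nitrogen. For the measured compounds named here, only one measured step touches this part of the molecule, the exchange of the whole aryl group from compound 1 to compound 2, and it was within the scatter. Compound 1 already carries chlorine on that ring, at a number close to that of compound 2. A step in this assay beyond the scatter is therefore not expected in either direction. Compound 3 is estimated at 3800 nM, in a range of 1500 nM to 9000 nM, a step of a 1.1-fold higher number from compound 2 to compound 3 (0.04 log units; within the scatter) from compound 2.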

Compound 3, half-maximal inhibitory concentration: 3800 nM
Compound 3: the middle estimate sits on the measured number at the digits printed; low and high end bracket the measured number.
By their numbers in this assay, from the lowest: compounds 2, 3 and 1 (each within the scatter of the next).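

In this assay, chloro in place of methoxy on the aromatic carbon gives a 1.1-fold higher number from compound 2 to compound 3 (0.04 log units; within the scatter), so this single exchange leaves the number within the scatter. Hydrogen in place of chloro gives a 1.1-fold lower number from compound 1 to compound 3 (0.04 log units; within the scatter), so compound 3 also matches compound 1 within the scatter with one chlorine fewer on the ring. The earlier step swapped the whole aryl group, changing the ring in more than one place, whereas these two steps each change one substituent, and neither moves the number beyond the scatter.

No measured information is available to explain these results. Still open, as far as these compounds go, is whether a group of a different kind at this ring carbon, such as an amine or a carboxylic acid, would shift the number beyond the scatter.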